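The source may hold more compounds than are shown below. What is called first, only, known or untested is meant among the compounds shown, and "the series" means these compounds.

Compound 2 `O=C(COc1cccc2ccccc12)N/N=C/c1ccc([N+](=O)[O-])cc1` gives 20 ug/mL in an ADME assay on HEL cells (Homo sapiens) for cytotoxicity; a lower number here means that less compound is tolerated, a higher number that more compound is tolerated. Compound 1 `C/C(=N\NC(=O)COc1cccc2ccccc12)c1ccc(C#N)cc1Br` gives 20 ug/mL in this assay, and compound 2 stands level with it at the digits shown, within the scatter. Compound 3 `C/C(=N\NC(=O)COc1cccc2ccccc12)c1ccc(Cl)cc1` gives only a limit, >= 4 ug/mL, in this assay. The step that the limit leaves unreadable from compound 1 to compound 3 is thus of unreadable size, since the limit of >= 4 ug/mL in this assay, at which 1 of the 3 values shown sits, hides its end. Compound 4 `O=C(COc1cccc2ccccc12)N/N=C/c1ccc(Br)cc1` differs from compound 2 by bromo in place of nitro on an aromatic carbon. Among the compounds with values here, no measured step bears directly on this exchange, and the one step recorded concerns other groups and cannot be read, so compound 2 alone guides the expectation, with no change beyond the scatter in this assay. Compound 4 is expected to give 20 ug/mL in this assay, between 10 ug/mL and 40 ug/mL. The expected step is no change at the digits printed from compound 2 to compound 4 (within the scatter).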

Compound 4, minimum cytotoxic concentration: > 100 ug/mL
Compound 4: only a limit was reported (the forecaster's own chance of this, stated with the estimate: 20%); middle value at least 5.0-fold (0.69 log units) from the limit.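

In this assay, the exchange on this aromatic carbon, para to a large group, proves not to be neutral: it gives an at least 5.0-fold higher number from compound 2 to compound 4 (0.69 log units; beyond the scatter). The one earlier step could not be read, so this is the only readable sign among the compounds shown that the group at this position matters. The full size of the step stays unknown, since compound 4 gives only a limit: the limit of > 100 ug/mL in this assay, at which 1 of the 4 values shown sits.

The compounds shown leave open how an amine or a carboxylic acid at this position would read. They also leave open whether bromo in place of nitro would give a similar step on the core of compound 1.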